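A Furan Ring Replaces an Aromatic Fluorophenyl Group

The source may hold more compounds than are shown below. What is called first, only, known or untested is meant among the compounds shown, and "the series" means these compounds.

Measured in an ADME assay on MDBK cells (Bos taurus) for cytotoxicity, read by MTT assay, with a stated time of 96 h; a lower number here means that less compound is tolerated, a higher number that more compound is tolerated
Compound 1 `FC(F)(F)c1cccc(NC(=S)Nc2cccc(Br)c2)c1` gives 10000 nM
Compound 2 `Fc1ccccc1NC(=S)Nc1cccc(C(F)(F)F)c1` gives > 100000 nM (a limit, not a number)

Compound 2 stands at the limit of > 100000 nM in this assay, at which 1 of the 2 values shown sits. Its true value is therefore not known as a number.

Compound 3 `FC(F)(F)c1cccc(NC(=S)NCc2ccco2)c1` keeps the shared core but carries (furan-2-yl)methyl in place of 2-fluorophenyl on an amide-type nitrogen. Going by the values given here, only one measured step bears on this change. It also swapped the group on an amide-type nitrogen, and it gave an at least 10-fold higher number from compound 1 to compound 2 (1.00 log units; beyond the scatter). That step shows that a swap at this kind of place can move the number well beyond the scatter, but a single step gives no firm rule for a furan-containing group.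

Among the compounds with values here, because compound 2 has > 100000 nM as its only reading, some caution is needed, and a modest step to a lower number in this assay is expected, though compound 3 may also reach the limit. The expected change is an at least 1.6-fold lower number from compound 2 to compound 3 (0.22 log units; that floor lies within the scatter). For compound 3 the estimated value is 60000 nM, with an expected range from 15000 nM to 100000 nM.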

Compound 3, half-maximal cytotoxic concentration: > 100000 nM
Compound 3 was reported as a limit; the forecaster's own chance of this, stated with the estimate: 50%; middle value at least 1.6-fold (0.22 log units) from the limit.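

In this assay compound 3 gives > 100000 nM, which is a limit of the assay and not a number. Its comparison with compound 1 can still be read: (furan-2-yl)methyl in place of 3-bromophenyl on the amide-type nitrogen gives an at least 10-fold higher number from compound 1 to compound 3 (1.00 log units; beyond the scatter), so a second, quite different group now stands well clear of compound 1, alongside the earlier at least 10-fold higher number from compound 1 to compound 2 (1.00 log units; beyond the scatter), and among these three compounds the 3-bromophenyl compound alone gives a readable number. The step between compound 2 and compound 3 cannot be read, and the reason lies in where both values sit: the limit of > 100000 nM in this assay, at which 2 of the 3 values shown sit.

As far as these compounds go, how far 2-fluorophenyl and (furan-2-yl)methyl really differ therefore stays open, as does whether the lower number of compound 1 belongs to its bromine or to the 3-bromophenyl group as a whole. From the compounds shown here alone, it is also open whether a plain phenyl, a longer alkyl chain or a group carrying a carboxylic acid on this same nitrogen would reach the limit or give a readable number, as compound 1 does.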